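A few compounds are considered here, and "the series" means these few. Any claim that something is new, unique, unknown or untested is made for them only; others in the source may bear on it.

Measured so far:
Compound 1 `COCCOC(=O)Nc1cc2nc(C3CCCCC3)[nH]c2cc1N1CCCC1`, for which an ADME assay on Vero cells (Chlorocebus sabaeus) for cytotoxicity, read by resazurin assay, with a stated time of 3 days (a higher number here means a weaker inhibitor, a lower number a stronger inhibitor), gives > 100 ug/mL, a limit of the assay and not a number.
Compound 2 `CCOCCOC(=O)Nc1cc2nc(C3CCCCC3)[nH]c2cc1N1CCCC1`, for which this assay gives > 100 ug/mL, again only a limit.
Compound 3 `CCOCCOC(=O)Nc1cc2nc(C3CCCCC3)[nH]c2cc1N(CC)CC`, for which this assay gives > 100 ug/mL, also a limit.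

Compound 2 thus stands where every value shown stands, namely (the limit of > 100 ug/mL in this assay, at which 3 of the 3 values shown sit). The two neighbouring steps, a step that the two limits leave unreadable from compound 1 to compound 2 and a step that the two limits leave unreadable from compound 2 to compound 3, are unreadable, since both ends sit at the limit. Compound 4 `CCCCNC(=O)Nc1cc2nc(C3CCCCC3)[nH]c2cc1N1CCCC1` differs from compound 2 at the carbonyl carbon: butylamino in place of 2-ethoxyethoxy on a carbonyl carbon. Going by the values given here, no measured step touches this position, so no readable step bears on it. Compound 2 itself shows only a limit, so compound 4 is expected to remain at or around that limit, with the expected step that the limit leaves unreadable from compound 2 to compound 4. Compound 4 is estimated at 120 ug/mL, in the range 60 ug/mL to 250 ug/mL.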

Compound 4, half-maximal inhibitory concentration: > 100 ug/mL
Compound 4 was reported as a limit (the forecaster's own chance of this, stated with the estimate: 75%); the middle value does not contradict the limit.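

No step among compound 1, compound 2 and compound 4 can be read, since each is reported only as a limit in this assay: the limit of > 100 ug/mL in this assay, at which 4 of the 4 values shown sit.

The compounds shown leave open what actual value any of them would give in this assay, and so whether the butylamino or 2-ethoxyethoxy group makes any difference there.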